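An Ester Gives Way to a Morpholine Amide

The source may hold more compounds than are shown below. What is called first, only, known or untested is meant among the compounds shown, and "the series" means these compounds.

Three measured compounds share one core. Compound 1 `CNC(=O)CCc1ccncc1-c1ccc2ccccc2c1`, compound 2 `COC(=O)/C=C/c1ccncc1-c1ccc2ccccc2c1` and compound 3 `NNC(=O)CCc1ccncc1-c1ccc2ccccc2c1` were tested in a functional assay on MCF7 cells (Homo sapiens) for inhibition, read by sulforhodamine B assay, with a stated time of 72 h; on this read-out higher numbers stand for weaker inhibition of growth and lower numbers for stronger inhibition of growth. For the measured compounds named here, compound 2 gives 8170 nM, the only outright number among the three. Compound 1 reaches only the limit of the assay, > 10000 nM. Compound 3 likewise stops at a limit, > 10000 nM. Two of the three results thus sit at the limit of > 10000 nM in this assay, at which 2 of the 3 values shown sit. Compound 4 `O=C(/C=C/c1ccncc1-c1ccc2ccccc2c1)N1CCOCC1` differs from compound 2 by morpholin-4-yl in place of methoxy on a carbonyl carbon. Going by the values given here, no measured step alters the ester alone; the nearest are an at least 1.2-fold lower number from compound 1 to compound 2 (0.08 log units; that floor lies within the scatter), which also changes the chain, and an at least 1.2-fold higher number from compound 2 to compound 3 (0.08 log units; that floor lies within the scatter), both resting on a limit and within the scatter. Compound 4 is therefore expected to move little: a 1.1-fold higher number from compound 2 to compound 4 (0.04 log units; within the scatter). The estimated value for compound 4 is 9000 nM, with a range from 4000 nM to 20000 nM.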

Compound 4, concentration for 50% growth inhibition: > 10000 nM
Compound 4 was reported as a limit; the forecaster's own chance of this, stated with the estimate: 40%; middle value at least 1.1-fold (0.04 log units) away from the limit.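

Compound 4 is the first case shown in which the group on the carbonyl carbon changes while the double-bonded chain stays the same. In this assay the change from methoxy to morpholin-4-yl gives an at least 1.2-fold higher number from compound 2 to compound 4 (0.08 log units; that floor lies within the scatter). The result for compound 4 is a limit of the assay, so this step sets only a floor, and compound 2 remains the only compound with an outright number: the limit of > 10000 nM in this assay, at which 3 of the 4 values shown sit.

Going by these compounds, how far compound 4 actually lies from compound 2 stays open. Also open, on these data alone, is whether a free carboxylic acid or a piperazine amide on the same chain would give an outright number.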